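The compounds below may be only part of what the source reports. "The series", "measured", "known", "first", "only" and "open" are said of these compounds alone.

Compound 1 `CCN(CC)S(=O)(=O)c1ccc(S(=O)(=O)N2CCC[C@@H](C(=O)NC3CN(C(=O)C4CC4)C3)C2)cc1`, compound 2 `CCN1CC(NC(=O)[C@@H]2CCCN(S(=O)(=O)c3ccc(S(=O)(=O)N(CC)CC)cc3)C2)C1` and compound 3 `CCN(CC)S(=O)(=O)c1ccc(S(=O)(=O)N2CCC[C@@H](C(=O)NC3CN(C(=O)NC(C)(C)C)C3)C2)cc1` share one core and differ only in the group on the nitrogen of the four-membered ring. In a functional assay on MIA PaCa-2 cells (Homo sapiens) for inhibition, read by MTT assay, with a stated time of 7 days (a higher number here means a weaker inhibitor, a lower number a stronger inhibitor), compound 1 gives 2800 nM. Compound 3 gives 3400 nM in this assay. For compound 2 this assay reports only a limit, > 30000 nM, not a number.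

Across the measured steps, an at least 10-fold higher number from compound 1 to compound 2 (1.02 log units; beyond the scatter) and an at least 8.8-fold lower number from compound 2 to compound 3 (0.94 log units; beyond the scatter), while a 1.2-fold higher number from compound 1 to compound 3 (0.08 log units; within the scatter). Among the two compounds with a number, compound 3 has the higher one, with compound 1 nearest and within the scatter.

Compound 4 `CCN(CC)S(=O)(=O)c1ccc(S(=O)(=O)N2CCC[C@@H](C(=O)NC3CN(S(C)(=O)=O)C3)C2)cc1` is not yet measured. The change is methylsulfonyl in place of (tert-butyl)carbamoyl on an amine nitrogen in a ring. Among the compounds with values here, the steps that bear on it are the two swaps on this ring nitrogen: exchanging one carbonyl-bearing group for another, from compound 1 to compound 3, stayed within the scatter, whereas putting a plain ethyl there, from compound 1 to compound 2 and back from compound 2 to compound 3, cost at least a large step. Methylsulfonyl is again a group bound through a double-bonded atom rather than a plain alkyl, so the step expected in this assay is a 1.0-fold higher number from compound 3 to compound 4 (0.01 log units; within the scatter), small and in no sure direction. Compound 4 is therefore estimated at 3500 nM, between 1200 nM and 10000 nM.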

Compound 4, half-maximal inhibitory concentration: 2500 nM
Compound 4: the middle estimate sits 1.4-fold (0.15 log units) above what was measured; low and high end bracket the measured number.
By their numbers in this assay, from the lowest: compounds 4, 1 and 3 (each within the scatter of the next). At a limit, above all of these: compound 2.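

In this assay, replacing the carbonyl-bearing group on the ring nitrogen with methylsulfonyl gives a 1.4-fold lower number from compound 3 to compound 4 (0.13 log units; within the scatter), and the second comparison gives a 1.1-fold lower number from compound 1 to compound 4 (0.05 log units; within the scatter). Compounds 1, 3 and 4 therefore show that, among the groups tested at this amine nitrogen of the four-membered ring, a sulfonyl group can serve as well as the two carbonyl-bearing groups, and that methylsulfonyl, with fewer heavy atoms and no hydrogen-bond donor, reads the same as (tert-butyl)carbamoyl within the scatter. Compound 2, with ethyl, stands apart, with an at least 12-fold lower number from compound 2 to compound 4 (1.07 log units; beyond the scatter), and its entry is a limit, not a number: the limit of > 30000 nM in this assay, at which 1 of the 4 values shown sits.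

The compounds shown leave open whether the loss belongs to ethyl alone or extends to other groups without a carbonyl or sulfonyl, such as a longer alkyl chain, a benzyl group or the bare ring amine. They also leave open how far the sulfonyl side can be taken, for example with a phenylsulfonyl group, or whether a carboxylic acid on a short chain at this nitrogen would fall with the first set or with ethyl.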